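The source may hold more compounds than are shown below. What is called first, only, known or untested is meant among the compounds shown, and "the series" means these compounds.

Working notes on the series. In a functional assay on isolated protein for agonist activity at Glucose-dependent insulinotropic receptor (Homo sapiens), read by HTRF and cAMP accumulation (on this read-out lower numbers stand for an effect already at smaller amounts and higher numbers for an effect only at larger amounts of compound), compound 1 `CC(C)(C)OC(=O)N1CCC(O[C@H]2CC[C@H](Oc3cnc(S(C)(=O)=O)cn3)CC2)CC1` gives 5.9 nM. Compound 2 `CS(=O)(=O)c1cnc(O[C@H]2CC[C@H](OC3CCN(C(=O)OC4CCOC4)CC3)CC2)cn1` gives 427 nM in this assay, and compound 3 `CS(=O)(=O)c1cnc(O[C@H]2CC[C@H](OC3CCN(CC4(C(F)(F)F)CC4)CC3)CC2)cn1` gives 62.6 nM, so compound 3 stands second highest of the three numbers, nearer to compound 2 than to compound 1. All measured steps concern the group on the amine nitrogen in the ring: a 72-fold higher number from compound 1 to compound 2 (1.86 log units; beyond the scatter), an 11-fold higher number from compound 1 to compound 3 (1.03 log units; beyond the scatter) and a 6.8-fold lower number from compound 2 to compound 3 (0.83 log units; beyond the scatter). Compound 4 `CS(=O)(=O)c1cnc(O[C@H]2CC[C@H](OC3CCN(CC4(C(F)(F)F)CCC4)CC3)CC2)cn1` differs from compound 3 by 1-(trifluoromethyl)cyclobutyl in place of 1-(trifluoromethyl)cyclopropyl on a saturated chain carbon bound to an amine nitrogen in a ring. Going by the values given here, no measured step changes a ring size at this position, so none bears directly on the move; a change within the scatter is expected, a 1.0-fold lower number from compound 3 to compound 4 (0.02 log units; within the scatter). Compound 4 is therefore estimated at 60 nM, with a range from 25 nM to 160 nM.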

Compound 4, half-maximal effective concentration: 54.8 nM
Beside the measured number, compound 4's estimate is 1.1-fold (0.04 log units) above it; the range from low to high includes it.
By their numbers in this assay, from the lowest: compound 1; then compounds 4 and 3 (each within the scatter of the next); then compound 2.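

In this assay the ring size within this group gets its first direct reading: 1-(trifluoromethyl)cyclobutyl in place of 1-(trifluoromethyl)cyclopropyl gives a 1.1-fold lower number from compound 3 to compound 4 (0.06 log units; within the scatter) and leaves the two groups indistinguishable here. Steps to the groups joined through a carbonyl stay beyond the scatter and run in the directions seen for compound 3, with a 7.8-fold lower number from compound 2 to compound 4 (0.89 log units; beyond the scatter) and a 9.3-fold higher number from compound 1 to compound 4 (0.97 log units; beyond the scatter) for the cyclobutyl group. No measurement at hand accounts for these results. Open, as far as these compounds go, is whether 1-(trifluoromethyl)cyclopentyl would fit the same reading. Also open, from the compounds shown here alone, is what an open alkyl chain or a plain cyclobutyl without trifluoromethyl would give.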